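Benzyl variations on a shared core, all below the assay ceiling

The source may hold more compounds than are shown below. What is called first, only, known or untested is meant among the compounds shown, and "the series" means these compounds.

Compound 2 `COc1ccccc1CNc1ncnc2c1ncn2[C@@H]1O[C@H](CO)[C@@H](O)[C@H]1O` is one of three close analogues tested in a functional assay on B16 cells (Mus musculus) for antiproliferative activity, with a stated time of 72 h; on this read-out lower numbers stand for stronger inhibition and higher numbers for weaker inhibition. In this assay compound 2 gives only a limit, > 166000 nM. Compound 1 `OC[C@H]1O[C@@H](n2cnc3c(NCc4ccccc4Cl)ncnc32)[C@H](O)[C@@H]1O` likewise gives only a limit in this assay, > 166000 nM. Compound 3 `OC[C@H]1O[C@@H](n2cnc3c(NCc4c(F)ccc(F)c4F)ncnc32)[C@H](O)[C@@H]1O` also gives only a limit in this assay, > 166000 nM. All three values thus sit at one point, as the limit of > 166000 nM in this assay, at which 3 of the 3 values shown sit, shows, and none of the steps between them can be read: a step that the two limits leave unreadable from compound 1 to compound 2, a step that the two limits leave unreadable from compound 1 to compound 3, a step that the two limits leave unreadable from compound 2 to compound 3. Compound 2 therefore stands nowhere in particular on the numbers shown; it simply shares a limit with its two neighbours.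

The unmeasured compound 4 `Cc1ccc(O)c(CNc2ncnc3c2ncn3[C@@H]2O[C@H](CO)[C@@H](O)[C@H]2O)c1` differs from compound 2 in one place: 2-hydroxy-5-methylphenyl in place of 2-methoxyphenyl on a saturated chain carbon bound to a nitrogen on an aromatic ring. The measured steps that bear on this change are the ones that alter the same benzyl group, from compound 1 to compound 2 and from compound 2 to compound 3, and both are left unreadable by the two limits. No readable step exists in this assay on which a direction could be built. Since every change at this group so far has left the value at the limit, compound 4 is expected to show a step that the limit leaves unreadable from compound 2 to compound 4, none beyond the scatter. Compound 4 is estimated at 200000 nM in this assay, within 90000 nM to 500000 nM, with a limit again the most likely outcome.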

Compound 4, half-maximal inhibitory concentration: > 166000 nM
Compound 4 gave a limit, no number (the forecaster's own chance of this, stated with the estimate: 85%); the middle value is on the limit's open side.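

Compound 4 gives only a limit in this assay, as do compound 1, compound 2 and compound 3, so none of the new steps to compound 4 can be read: the limit of > 166000 nM in this assay, at which 4 of the 4 values shown sit.

The compounds shown leave open whether any change at this benzyl group moves the value in this assay at all, and in which direction.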